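The source may report more compounds than this note shows. Statements on the series, on what has been measured and on what is new or still open speak of the compounds shown alone.

Measured so far:
compound 1 `O=CN(C1CCCC1)C1CCCC1`: 1000000 nM
compound 2 `O=CN(C1CCCC1)C1CC1`: 4600 nM

In an assay on isolated protein for inhibition of alcohol dehydrogenase 1C (Homo sapiens) (a higher number here means a weaker inhibitor, a lower number a stronger inhibitor), compound 2 gives 4600 nM, the lowest of the two numbers; compound 1 gives 1000000 nM, a gap well beyond the scatter. Compound 3 `O=CN(C1CCCC1)C1CCC1` differs from compound 2 by cyclobutyl in place of cyclopropyl on an amide-type nitrogen. Among the compounds with values here, no step between two measured compounds is available here. Because compound 1 gives 1000000 nM in this assay, the move toward a larger ring is expected to raise the number beyond the scatter, though by far less than the gap to compound 1. Compound 3 is expected at 30000 nM, range 5000 nM to 250000 nM. This corresponds to an expected step of a 6.5-fold higher number from compound 2 to compound 3 (0.81 log units; beyond the scatter).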

Compound 3, inhibition constant: 47000 nM
Estimate against measurement, compound 3: 1.6-fold (0.19 log units) below, and the stated range covers the measured number.
By their numbers in this assay, from the lowest: compound 2; then compound 3; then compound 1.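

In this assay, cyclobutyl in place of cyclopropyl on the amide-type nitrogen gives a 10-fold higher number from compound 2 to compound 3 (1.01 log units; beyond the scatter), so this position responds strongly even to a change of ring size within small carbon rings. Compound 3 falls between compound 2 and compound 1 in the printed values, and the number rises in step with ring size across these three compounds, with none going against that order. No available evidence bears on this step.
Going by these compounds, whether an open-chain group such as isopropyl, or an oxygen-containing ring such as oxetanyl, would be tolerated on this nitrogen remains open. On these data alone, the effect of replacing the cyclopentyl group shared by compound 2 and compound 3 also remains open.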